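The source may report more compounds than this note shows. Statements on the series, on what has been measured and on what is new or still open speak of the compounds shown alone.

Compound 1 `CCN(CC)CN1C(=O)/C(=N/NC(=S)Nc2ccccc2)c2cc(Cl)ccc21` gives >= 800 nM in an ADME assay on MDCK cells (Canis lupus familiaris) for cytotoxicity (on this read-out higher numbers stand for lower toxicity in this test and lower numbers for higher toxicity in this test), a limit of the assay rather than a number.
Compound 2 `CCN(CC)CN1C(=O)/C(=N/NC(N)=S)c2cc(Cl)ccc21` gives 100000 nM.
Compound 3 `CCN(CC)CN1C(=O)/C(=N/NC(=S)Nc2ccccc2)c2ccccc21` gives 800 nM.

Going by the values given here, compound 3 stands lowest of the two numbers in this assay; the nearest, compound 2, sits far higher, a gap beyond the scatter, but the two differ in two places and no single step links them. Compound 4 `CCN(CC)CN1C(=O)/C(=N/NC(N)=S)c2ccccc21` differs from compound 3 by hydrogen in place of phenyl on an amide-type nitrogen. Among the compounds with values here, the one measured step of the same kind, a step that the limit leaves unreadable from compound 1 to compound 2, cannot be read because of the limit of >= 800 nM in this assay, at which 1 of the 3 values shown sits, so its size stays open. Within the data shown here, the expectation rests on compound 2, whose 100000 nM is the only number seen with the amino group. Compound 4 is therefore expected to give 50000 nM, within 8000 nM to 200000 nM, an expected step of a 63-fold higher number from compound 3 to compound 4 (1.80 log units; beyond the scatter).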

Compound 4, minimum cytotoxic concentration: 100000 nM
Estimate against measurement, compound 4: 2.0-fold (0.30 log units) below; low and high end bracket the measured number.
By their numbers in this assay, from the lowest: compound 3; then compounds 2 and 4 (each within the scatter of the next).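

In this assay, the change from anilino to amino now has a readable size, with a 130-fold higher number from compound 3 to compound 4 (2.10 log units; beyond the scatter), where the earlier pair on the chloro core could not be read. Hydrogen in place of chloro on an aromatic carbon gives no change at the digits printed from compound 2 to compound 4 (within the scatter), so on the amino compounds this position shows no effect. Whether the same holds on the anilino compounds stays unsettled: the same change on two cores in this assay, a number no higher (the limit leaves the size open) from compound 1 to compound 3 and no change at the digits printed (within the scatter) from compound 2 to compound 4; the limit leaves it open whether they differ

The compounds shown leave open what a methyl or a benzyl group would give on this nitrogen in place of the phenyl, and so whether the low number needs an aromatic ring there.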